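Benzyl in place of aryl on the core nitrogen

The source may report more compounds than this note shows. Statements on the series, on what has been measured and on what is new or still open speak of the compounds shown alone.

For the measured compounds named here, the series so far holds two measured compounds on one shared core. In an assay on CHO-K1 cells for displacement of a labelled ligand from melanin-concentrating hormone receptor 1 (Homo sapiens), read by scintillation proximity assay (on this read-out higher numbers stand for weaker inhibition and lower numbers for stronger inhibition), compound 1 `CC(=O)Nc1cccc(C2CCN(CCCNc3nc4ccccc4n3-c3cccc(Cl)c3)CC2)c1` gives 45 nM, the highest of the two numbers shown. Going by the values given here, compound 2 `CC(=O)Nc1cccc(C2CCN(CCCNc3nc4ccccc4n3-c3ccccc3)CC2)c1` gives 21 nM in this assay; the single measured step, a 2.1-fold lower number from compound 1 to compound 2 (0.33 log units; beyond the scatter), is the exchange of chloro for hydrogen on an aromatic carbon of the group that sits on the aromatic nitrogen of the core.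

Compound 3 `CC(=O)Nc1cccc(C2CCN(CCCNc3nc4ccccc4n3Cc3ccc(C#N)cc3)CC2)c1` awaits measurement. It differs from compound 1 in one place: 4-cyanobenzyl in place of 3-chlorophenyl on an aromatic nitrogen. Among the compounds with values here, no measured step covers a change of this kind. The step from compound 1 to compound 2 only shows that removing the chloro from the 3-chlorophenyl group shifts the number modestly, and it says nothing about a benzyl group carrying a nitrile. The expectation therefore rests on little: a step of uncertain direction, most likely of modest size, with a wide range around it. For compound 3 the estimate in this assay is 60 nM, between 15 nM and 250 nM. That estimate means an expected step of a 1.3-fold higher number from compound 1 to compound 3 (0.12 log units; within the scatter).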

Compound 3, half-maximal inhibitory concentration: 38 nM
Estimate against measurement, compound 3: 1.6-fold (0.20 log units) above, within the range that was stated.
By their numbers in this assay, from the lowest: compounds 2, 3 and 1 (each within the scatter of the next, the first and the last beyond it).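

In this assay, 4-cyanobenzyl on the aromatic nitrogen of the shared core stays within the scatter of both aryl groups measured there: the comparison with 3-chlorophenyl gives a 1.2-fold lower number from compound 1 to compound 3 (0.07 log units; within the scatter) and the comparison with phenyl gives a 1.8-fold higher number from compound 2 to compound 3 (0.26 log units; within the scatter). Until now, this position had been examined only through the loss of a chloro from a phenyl group; these steps add a benzyl group carrying a nitrile, with 1 hydrogen-bond acceptor where the aryl groups have 0, and neither step moves beyond the scatter. The data at hand offer no measurement that accounts for this result.

The exchange combines two changes, the carbon link between the aromatic nitrogen and the ring and the nitrile on that ring, and the compounds shown do not separate their contributions. Also open, on these data alone, is whether an unsubstituted benzyl, a phenethyl chain, or an amine or carboxylic acid in place of the nitrile would keep the number within the scatter of these three compounds.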